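Alanine for glycine in a dipeptide-like cytotoxicity series

A few compounds are considered here, and "the series" means these few. Any claim that something is new, unique, unknown or untested is made for them only; others in the source may bear on it.

The series is read in an ADME assay on NIH3T3 cells (Mus musculus) for cytotoxicity, read by crystal violet staining; a higher number here means a weaker inhibitor, a lower number a stronger inhibitor. Compound 1 `COc1ccc(CNC(=O)C(CC(C)C)NC(=O)CNC(=O)OCc2ccccc2)cc1` reaches only a limit of the assay, > 100000 nM, and no number. Within the data shown here, compound 2 `CCCCCCCCCC(NC(=O)CNC(=O)OCc1ccccc1)C(=O)NCc1ccc(OC)cc1` gives 55000 nM in this assay, the only number among the two values. The other value, that of compound 1, is a limit (the limit of > 100000 nM in this assay, at which 1 of the 2 values shown sits). Among the measured compounds shown here, the single measured step, an at least 1.8-fold lower number from compound 1 to compound 2 (0.25 log units; that floor lies within the scatter), is itself bounded by that limit and cannot be sized further. Compound 3 `CCCCCCCCCC(NC(=O)[C@H](C)NC(=O)OCc1ccccc1)C(=O)NCc1ccc(OC)cc1` differs from compound 2 by methyl in place of hydrogen on a saturated chain carbon bound to an amide-type nitrogen and a carbonyl carbon. For the measured compounds named here, no measured step touches this position; the one step known concerns the octyl chain of compound 2 and does not carry over. The added methyl is the smallest possible change and no effect beyond the scatter is expected in this assay; the step from compound 2 to compound 3 is estimated as no change at the digits printed from compound 2 to compound 3 (within the scatter). Compound 3 is therefore expected to give about 55000 nM, within a range of 20000 nM to 150000 nM.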

Compound 3, half-maximal inhibitory concentration: 150000 nM
Estimate against measurement, compound 3: 2.7-fold (0.44 log units) below; the measured number falls inside the stated range.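

Among these compounds, at the saturated chain carbon bound to an amide-type nitrogen and a carbonyl carbon, the earlier compounds offered no measured step. With the octyl chain held constant, methyl in place of hydrogen gives a 2.7-fold higher number from compound 2 to compound 3 (0.44 log units; beyond the scatter) in this assay, so this position responds to the smallest possible change, and the move is towards a weaker inhibitor. Nothing measured here gives a cause for this step.

The compounds shown leave open whether a larger group on this carbon, such as an ethyl or a longer chain, or a charged one, such as an amine or a carboxylic acid, would move the number further or reverse it. Also open, as far as these compounds go, is whether the opposite configuration at this carbon gives the same reading as the methyl of compound 3.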